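Shifting the methoxy group around the aromatic ring

This account rests on a few compounds, and the source may have more. Where it says the series, first, only, none or still open, it means among the compounds named here.

For the measured compounds named here, in an assay on CHO cells for displacement of a labelled ligand from prostaglandin E2 receptor EP3 subtype (Mus musculus) (on this read-out higher numbers stand for weaker inhibition and lower numbers for stronger inhibition), compound 2 `COc1ccccc1C[C@H](O)/C=C/[C@H]1[C@H](O)CC(=O)[C@@H]1SCCCSCC(=O)O` gives 1100 nM, the lowest of the two numbers known here. Going by the values given here, its only neighbour is compound 1 `CCOCc1cccc(C[C@H](O)/C=C/[C@H]2[C@H](O)CC(=O)[C@@H]2SCCCSCC(=O)O)c1`, which in this assay gives 4500 nM; the step of a 4.1-fold lower number from compound 1 to compound 2 (0.61 log units; beyond the scatter) came from swapping one aromatic group for another at the same position on the chain. Compound 3 `COc1ccc(C[C@H](O)/C=C/[C@H]2[C@H](O)CC(=O)[C@@H]2SCCCSCC(=O)O)cc1` is built from the same atoms as compound 2, but arranged differently: 4-methoxyphenyl in place of 2-methoxyphenyl on a saturated chain carbon, two bonds along the chain from a double-bonded chain carbon and an oxygen on a saturated carbon. Among the compounds with values here, no measured step reports what moving the methoxy group to a different position on the ring does; the step from compound 1 to compound 2 changed both the group and its position at once, so it offers only a loose guide to the size that such a change can take. A modest step in either direction is therefore plausible, and compound 3 is expected to give about 2500 nM, which means a step of a 2.3-fold higher number from compound 2 to compound 3 (0.36 log units; beyond the scatter), with a range from 700 nM to 9000 nM.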

Compound 3, inhibition constant: 220 nM
The estimate for compound 3 lay 11-fold (1.06 log units) above the measured number, and the stated range ends above it.
By their numbers in this assay, from the lowest: compound 3; then compound 2; then compound 1.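

Moving the methoxy group with no change in atoms gives a 5.0-fold lower number from compound 2 to compound 3 (0.70 log units; beyond the scatter) in this assay, so the group's place on the ring matters by itself at this position on the chain. The earlier step could not show this, since it changed the group and its place together. Compound 3 now has the lowest number of the three, and replacing 3-(ethoxymethyl)phenyl with 4-methoxyphenyl gives a 20-fold lower number from compound 1 to compound 3 (1.31 log units; beyond the scatter), yet no measurement shown here accounts for either step.

As far as these compounds go, it remains open whether the 4-methoxyphenyl group is the best choice at this place, or whether a plain phenyl ring or a 4-ethoxyphenyl group, with its longer chain on the oxygen, would give a lower or higher number. For the compounds shown here, with only three compounds, no general rule for this position can be drawn.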